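Methoxy in place of hydrogen on the shared core

A few compounds are considered here, and "the series" means these few. Any claim that something is new, unique, unknown or untested is made for them only; others in the source may bear on it.

Compound 2 `Cc1ccc(-c2nn(-c3ccccc3)cc2C2CC(c3ccccc3)=NN2c2ccc(S(N)(=O)=O)cc2)cc1` in an ADME assay on Vero cells (Chlorocebus sabaeus) for cytotoxicity, read by MTT assay, with a stated time of 72 h (on this read-out higher numbers stand for lower toxicity in this test and lower numbers for higher toxicity in this test), is reported only as a limit, > 161000 nM. Compound 1 `COc1ccc(C2=NN(c3ccc(S(N)(=O)=O)cc3)C(c3cn(-c4ccccc4)nc3-c3ccccc3)C2)cc1` gives 40200 nM in this assay. Compound 2 thus stands at the limit of > 161000 nM in this assay, at which 1 of the 2 values shown sits. Compound 3 `COc1ccc(C2=NN(c3ccc(S(N)(=O)=O)cc3)C(c3cn(-c4ccccc4)nc3-c3ccc(C)cc3)C2)cc1` carries methoxy in place of hydrogen on an aromatic carbon relative to compound 2. Among the compounds with values here, no measured pair shows what this change does in this assay, so the step from compound 2 to compound 3 is expected to be modest, toward lower numbers, with an at least 1.7-fold lower number from compound 2 to compound 3 (0.25 log units; that floor lies within the scatter) as the estimated size. Compound 3 is expected at 90000 nM, within 25000 nM to 200000 nM.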

Compound 3, half-maximal cytotoxic concentration: > 36600 nM
Compound 3: only a limit was reported; the forecaster's own chance of this, stated with the estimate: 35%; the middle value is on the limit's open side.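

In this assay, within the data shown here, compound 3 is reported only as a limit, > 36600 nM, and no step from compound 1 or compound 2 to compound 3 can be read. The compounds shown leave open what methoxy in place of hydrogen on an aromatic carbon does in this assay.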